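Notes on a fluoro-for-hydrogen step in the acid series

The source may report more compounds than this note shows. Statements on the series, on what has been measured and on what is new or still open speak of the compounds shown alone.

Measured so far:
compound 1, `O=C(O)Cc1sc(CS(=O)(=O)c2ccc(Cl)cc2)nc1-c1ccc(Cl)cc1`: 30%
compound 2, `O=C(O)Cc1sc(C(c2ccc(F)cc2)c2ccc(F)cc2)nc1-c1cccc(F)c1`: 80%

Among the measured compounds shown here, in an in vitro functional assay on HEK285-7 cells for antagonist activity at prostaglandin D2 receptor 2 (Homo sapiens), read by BRET and beta-arrestin recruitment (a lower number here means a smaller maximal response, a higher number a larger maximal response), compound 2 gives 80%, the higher of the two numbers measured so far. Compound 1 gives 30%, and the gap between the two lies beyond the usual scatter, so compound 2 stands clearly above compound 1. For the measured compounds named here, no pair of measured compounds differs in a single place, so no measured step is available to lean on.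

Compound 3, `O=C(O)Cc1sc(C(c2ccc(F)cc2)c2ccc(F)cc2)nc1-c1cc(F)cc(F)c1`, differs from compound 2 by fluoro in place of hydrogen on an aromatic carbon, read one bond further out as 3-fluorophenyl to 3,5-difluorophenyl. Nothing in the two measured values bears on this change. The expected step from compound 2 to compound 3 is a number 2 percentage points lower from compound 2 to compound 3 (within the scatter), a change of no size beyond the scatter and of no fixed direction. For compound 3 the maximal response is estimated at 78%, with a range from 60% to 95%.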

Compound 3, largest response reached (reported as efficacy), in percent of the reference or control that the assay uses: 80%
Beside the measured number, compound 3's estimate is 2 percentage points below it; the range from low to high includes it.
By their numbers in this assay, from the lowest: compound 1; then compounds 2 and 3 (each within the scatter of the next).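

In this assay, among the compounds shown here, the change from 3-fluorophenyl to 3,5-difluorophenyl gives no change at the digits printed from compound 2 to compound 3 (within the scatter) and is the only single-place step so far. It shows that, with compound 2 as the starting point, fluoro in place of hydrogen on this aromatic carbon, meta to a fluoro group, leaves the maximal response unmoved, which compound 1 and compound 2 could not show since they differ in more than one place. No measurement at hand bears on why this step is flat.

From the compounds shown here alone, whether a larger or different group at this place, such as methoxy or an amine, would leave the response equally unmoved remains open. Also open, going by these compounds, is whether the same fluoro step would read alike on the core of compound 1.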